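The source may report more compounds than this note shows. Statements on the series, on what has been measured and on what is new or still open speak of the compounds shown alone.

In a functional assay on CAPAN-1 cells (Homo sapiens) for antiproliferative activity, with a stated time of 72 h (on this read-out higher numbers stand for weaker inhibition and lower numbers for stronger inhibition), compound 1 `Nc1ncnn2c([C@@H]3O[C@H](CO)[C@@H](O)[C@H]3O)cc(C#Cc3ccc(F)cc3)c12` gives 55400 nM, and compound 2 `Nc1ncnn2c([C@@H]3O[C@H](CO)[C@@H](O)[C@H]3O)cc(-c3ccc(Cl)cc3)c12` gives 56700 nM. Going by the values given here, the single step that connects them, a 1.0-fold higher number from compound 1 to compound 2 (0.01 log units; within the scatter), is a change of no consequence on this read-out, so compound 2 shares the weak end of the two numbers with compound 1 and neither can be called the weaker of the pair.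

Compound 3 `Nc1ncnn2c([C@@H]3O[C@H](CO)[C@@H](O)[C@H]3O)cc(-c3ccccc3F)c12` differs from compound 2 in one place: 2-fluorophenyl in place of 4-chlorophenyl on an aromatic carbon. Among the compounds with values here, no measured step bears directly on this exchange; the only step available, a 1.0-fold higher number from compound 1 to compound 2 (0.01 log units; within the scatter), concerns a different group at the same aromatic carbon and was flat. With two very weak values and one flat step, no movement beyond the scatter is expected in this assay, so compound 3 is estimated to give 60000 nM (range 25000 nM to 150000 nM), which means an expected step of a 1.1-fold higher number from compound 2 to compound 3 (0.02 log units; within the scatter).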

Compound 3, half-maximal inhibitory concentration: > 100000 nM
Compound 3: no number, only a limit; the forecaster's own chance of this, stated with the estimate: 25%; middle value at least 1.6-fold (0.22 log units) away from the limit.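

Compound 3 reaches no number in this assay, only a limit of the assay: the limit of > 100000 nM in this assay, at which 1 of the 3 values shown sits. Placing 2-fluorophenyl on this aromatic carbon gives an at least 1.7-fold higher number from compound 2 to compound 3 (0.24 log units; that floor lies within the scatter), and against the ethynyl group it gives an at least 1.8-fold higher number from compound 1 to compound 3 (0.25 log units; that floor lies within the scatter). Both floors lie within the scatter, so this position is still not shown to separate the three groups, and the new result adds only that one aryl group here leaves the read-out at the limit, with no upper bound on how large the steps are.

Going by these compounds, how far compound 3 lies past its limit stays open, and a 4-fluorophenyl group would be needed to tell the halogen from its place on the ring. Also open, on these data alone, is whether a non-aryl group on this carbon, such as an amine or a carboxylic acid, would give stronger inhibition than these weak values.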